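The source may report more compounds than this note shows. Statements on the series, on what has been measured and on what is new or still open speak of the compounds shown alone.

Of the compounds shown here, three built on one shared core have been measured in an assay on HEK293 cells for displacement of a labelled ligand from NPC1-like intracellular cholesterol transporter 1 (Homo sapiens); on this read-out lower numbers stand for stronger inhibition and higher numbers for weaker inhibition. Compound 1 `CC(C)(C)c1ccc(C(=O)N2CCC3(CC2)C(=O)N(CC(=O)NCCO)CN3c2ccccc2)cc1` gives 1000 nM. Compound 2 `CC(C)(C)c1ccc(C(=O)N2CCC3(CC2)C(=O)N(CC(=O)N2CCCC(C(N)=O)C2)CN3c2ccccc2)cc1` gives 16900 nM, and compound 3 `CC(C)(C)OC(=O)NCCNC(=O)CN1CN(c2ccccc2)C2(CCN(C(=O)c3ccc(C(C)(C)C)cc3)CC2)C1=O` gives 10900 nM. Compound 3 therefore stands second highest of the three numbers: compound 2 lies closest, at a 1.6-fold lower number from compound 2 to compound 3 (0.19 log units; within the scatter), while compound 1 lies furthest, at an 11-fold higher number from compound 1 to compound 3 (1.04 log units; beyond the scatter).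

Compound 4 `CCOC(=O)C1CCN(C(=O)CN2CN(c3ccccc3)C3(CCN(C(=O)c4ccc(C(C)(C)C)cc4)CC3)C2=O)CC1` has not yet been measured. It differs from compound 3 in a single place: 4-(ethoxycarbonyl)piperidin-1-yl in place of (2-((tert-butoxycarbonyl)amino)ethyl)amino on a carbonyl carbon.

For the measured compounds named here, two measured steps bear on this change. The step of a 17-fold higher number from compound 1 to compound 2 (1.23 log units; beyond the scatter) shows that exchanging an open chain on that carbonyl carbon for a 3-carbamoylpiperidin-1-yl ring raised the number sharply. The step of a 1.6-fold lower number from compound 2 to compound 3 (0.19 log units; within the scatter) shows that a 3-carbamoylpiperidin-1-yl ring and a (2-((tert-butoxycarbonyl)amino)ethyl)amino chain give much the same number. Compound 4 carries a 4-(ethoxycarbonyl)piperidin-1-yl ring, so the closest comparison is compound 2, whose number in this assay is 16900 nM.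

The step expected from compound 3 is therefore a 1.4-fold higher number from compound 3 to compound 4 (0.14 log units; within the scatter), staying within the usual scatter. Compound 4 is expected to give an estimated 15000 nM, with a range from 5000 nM to 45000 nM.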

Compound 4, half-maximal inhibitory concentration: 3100 nM
For compound 4 the middle estimate is 4.8-fold (0.68 log units) above the measured one; measured number below the stated range.
By their numbers in this assay, from the lowest: compound 1; then compound 4; then compounds 3 and 2 (each within the scatter of the next).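

In this assay, a piperidine ring on this carbonyl carbon does not by itself bring a high number: a 5.5-fold lower number from compound 2 to compound 4 (0.74 log units; beyond the scatter) shows that the two ring-bearing groups differ clearly. Size does not settle the matter either, since a 3.5-fold lower number from compound 3 to compound 4 (0.55 log units; beyond the scatter) comes with an exchange that keeps 11 heavy atoms and 2 hydrogen-bond acceptors, while a six-membered ring enters and the 2 hydrogen-bond donors leave. Even so, the ester-bearing ring does not match the short hydroxy chain, as a 3.1-fold higher number from compound 1 to compound 4 (0.49 log units; beyond the scatter) shows, and compound 1 keeps the lowest number of the four.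

Nothing shown here gives a measured reason for these differences. The names 3-carbamoylpiperidin-1-yl and 4-(ethoxycarbonyl)piperidin-1-yl differ in both the group on the ring and its numbered place, so the compounds shown leave open which of the two matters, and 4-carbamoylpiperidin-1-yl or 3-(ethoxycarbonyl)piperidin-1-yl would separate them, while 4-carboxypiperidin-1-yl, with a carboxylic acid in place of the ethyl ester, would test whether the ester itself is needed.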